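Extending the Hydroxyalkyl Chain of Compound 3

The source may report more compounds than this note shows. Statements on the series, on what has been measured and on what is new or still open speak of the compounds shown alone.

Compound 1, `COc1nc2ccc(Br)cc2cc1C(c1ccccc1)n1cc(-c2ccc(Br)cc2)nn1`, gives 13.4% in an ADME assay on SK-OV-3 cells (Homo sapiens) for cytotoxicity, read by sulforhodamine B assay, with a stated time of 48 h, tested at 10 uM; on this read-out higher numbers stand for more inhibition at the one concentration tested (going by the name of the read-out) and lower numbers for less inhibition.
Compound 2, `COc1nc2ccc(Br)cc2cc1C(c1ccccc1)n1cc(-c2ccccc2F)nn1`, gives 7.33% in this assay.
Compound 3, `COc1nc2ccc(Br)cc2cc1C(c1ccccc1)n1cc(CCCO)nn1`, gives 13.8% in this assay.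

Compound 3 stands at the top of these three numbers, yet a number 0.4 percentage points higher from compound 1 to compound 3 (within the scatter) and a number 6.5 percentage points higher from compound 2 to compound 3 (within the scatter) both lie within the scatter, as does a number 6.1 percentage points lower from compound 1 to compound 2 (within the scatter); the three compounds are not separated by this assay. Compound 4, `COc1nc2ccc(Br)cc2cc1C(c1ccccc1)n1cc(CCCCCO)nn1`, differs from compound 3 by 2-hydroxyethyl in place of hydroxy on a saturated chain carbon, three bonds along the chain from an aromatic carbon. For the measured compounds named here, no measured step alters a chain in this way; each swaps the whole group on the aromatic carbon, and none moved the number beyond the scatter. Compound 4 is therefore expected to give 13% in this assay, within 2% to 26%. This estimate means a number 0.8 percentage points lower from compound 3 to compound 4 (within the scatter), a step not expected to exceed the scatter.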

Compound 4, a percentage reported as inhibition, at one concentration (the size of the read-out at that concentration, not a potency): 8.69%
Compound 4: the middle estimate sits 4.3 percentage points above what was measured; the measured number falls inside the stated range.
By their numbers in this assay, from the lowest: compounds 2, 4, 1 and 3 (each within the scatter of the next).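

Going from 3-hydroxypropyl to 5-hydroxypentyl gives a number 5.1 percentage points lower from compound 3 to compound 4 (within the scatter) in this assay, so the first change made within the chain, rather than of the whole group on the aromatic carbon, also fails to separate two compounds. Set against the aryl groups, the 5-hydroxypentyl group gives a number 1.4 percentage points higher from compound 2 to compound 4 (within the scatter) and a number 4.7 percentage points lower from compound 1 to compound 4 (within the scatter) on the same read-out. No available evidence bears on this result.

The compounds shown leave open whether an amine or a carboxylic acid in place of the hydroxy, or a still longer chain, would move the number in this assay beyond the scatter.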